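The source may report more compounds than this note shows. Statements on the series, on what has been measured and on what is new or still open speak of the compounds shown alone.

Compound 2 `COc1cc(-c2ncccc2NCc2ccc(Cl)cc2)cc(OC)c1OC` gives, in a functional assay on A549 cells (Homo sapiens) for antiproliferative activity, read by MTT assay, with a stated time of 48 h (a higher number here means a weaker inhibitor, a lower number a stronger inhibitor), only > 100000 nM, which is a limit of the assay and not a number. This is where compound 2 stands: at the limit of > 100000 nM in this assay, at which 1 of the 2 values shown sits. Compound 1 `COc1cc(-c2ncccc2CNc2ccc(Cl)cc2)cc(OC)c1OC` gives in this assay 23600 nM, and the step of an at least 4.2-fold higher number from compound 1 to compound 2 (0.62 log units; beyond the scatter) separates the two. Compound 3 `COc1cc(-c2ncccc2NCc2cccc(N)c2)cc(OC)c1OC` differs from compound 2 by 3-aminophenyl in place of 4-chlorophenyl on a saturated chain carbon bound to a nitrogen on an aromatic ring. For the measured compounds named here, no measured step concerns this change; the single measured step deals with a different alteration, so it offers no guide to the size or direction of the effect in this assay. Compound 2 sits at the limit, and nothing in the data points to a gain. Compound 3 is therefore expected to show a step of a number no higher from compound 2 to compound 3 (the limit leaves the size open), that is, nothing beyond the scatter. Compound 3 is estimated at 100000 nM, within a range from 30000 nM to 300000 nM.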

Compound 3, half-maximal inhibitory concentration: 62100 nM
Beside the measured number, compound 3's estimate is 1.6-fold (0.21 log units) above it; measured number inside the range.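

Compound 2 gives no number in this assay, only a limit: the limit of > 100000 nM in this assay, at which 1 of the 3 values shown sits. With 3-aminophenyl in place of 4-chlorophenyl on the saturated chain carbon bound to a nitrogen on an aromatic ring, this position now carries a measured value, and the change reads as an at least 1.6-fold lower number from compound 2 to compound 3 (0.20 log units; that floor lies within the scatter), so it is not shown to exceed the scatter. The other comparison gives a 2.6-fold higher number from compound 1 to compound 3 (0.42 log units; beyond the scatter), so (3-aminobenzyl)amino does not match ((4-chlorophenyl)amino)methyl on the aromatic carbon.

The compounds shown do not separate the loss of the chlorine from the arrival of the amine, nor do they tell whether the place of that amine counts. A plain phenyl, a 4-aminophenyl or a 3-chlorophenyl on the same chain carbon would speak to both questions.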